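A few compounds are considered here, and "the series" means these few. Any claim that something is new, unique, unknown or untested is made for them only; others in the source may bear on it.

The compounds share one core and differ only in the aromatic group attached to the carbonyl of the amide. For the measured compounds named here, compound 3, `O=C(Nc1cccc(-c2oc3cc(-c4ccc(F)cc4)ccc3c(=O)c2O)c1)c1ccc(F)cc1F`, carries a 2,4-difluorophenyl there, and in a functional assay on HCC1937 cells (Homo sapiens) for antiproliferative activity, read by CCK-8 assay, with a stated time of 72 h (on this read-out higher numbers stand for weaker inhibition and lower numbers for stronger inhibition), compound 3 gives 6980 nM, the lowest of the numbers measured so far. Compound 1, `O=C(Nc1cccc(-c2oc3cc(-c4ccc(F)cc4)ccc3c(=O)c2O)c1)c1ccccc1F`, with a 2-fluorophenyl, gives 10800 nM in this assay, and compound 2, `O=C(Nc1cccc(-c2oc3cc(-c4ccc(F)cc4)ccc3c(=O)c2O)c1)c1ccc(F)cc1`, with a 4-fluorophenyl, gives 14200 nM. The step of a 1.3-fold higher number from compound 1 to compound 2 (0.12 log units; within the scatter) shows that relocating the single fluoro made no difference the assay can resolve; the step of a 2.0-fold lower number from compound 2 to compound 3 (0.31 log units; beyond the scatter) was modest, and the step of a 1.5-fold lower number from compound 1 to compound 3 (0.19 log units; within the scatter) stayed within the scatter.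

Compound 4, `O=C(Nc1cccc(-c2oc3cc(-c4ccc(F)cc4)ccc3c(=O)c2O)c1)c1ccc(C(F)(F)F)cc1`, is the next compound: 4-(trifluoromethyl)phenyl in place of 2,4-difluorophenyl on a carbonyl carbon. Going by the values given here, no measured pair swaps a fluoro for a trifluoromethyl, so the only steps that bear on it are those above, all within or barely beyond the scatter. Losing the fluoro that entered in the step from compound 2 to compound 3 would, read backwards, point to a somewhat higher number, while the trifluoromethyl is uncharted. Compound 4 is therefore expected to show a 1.6-fold higher number from compound 3 to compound 4 (0.20 log units; within the scatter), a step at the edge of the scatter and towards weaker inhibition. For compound 4 the estimated value in this assay is 11000 nM, with a range from 4500 nM to 27000 nM.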

Compound 4, half-maximal inhibitory concentration: 7350 nM
The estimate for compound 4 lay 1.5-fold (0.18 log units) above the measured number; the range from low to high includes it.
By their numbers in this assay, from the lowest: compounds 3, 4, 1 and 2 (each within the scatter of the next, the first and the last beyond it).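

In this assay, the place on the carbonyl carbon took 4-(trifluoromethyl)phenyl in place of 2,4-difluorophenyl with no difference the assay can resolve (a 1.1-fold higher number from compound 3 to compound 4 (0.02 log units; within the scatter)), so the second fluoro of compound 3 is not the only arrangement compatible with a number in this range. Trifluoromethyl in place of fluoro on the aromatic carbon, a change the earlier compounds did not include, stayed just inside the scatter (a 1.9-fold lower number from compound 2 to compound 4 (0.29 log units; within the scatter)), and the step from the 2-fluorophenyl amide was smaller still (a 1.5-fold lower number from compound 1 to compound 4 (0.17 log units; within the scatter)). For the compounds shown here, compound 4 therefore joins a narrow band of fluorinated phenyl amides in which the only step beyond the scatter remains the modest one already seen (a 2.0-fold lower number from compound 2 to compound 3 (0.31 log units; beyond the scatter)).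

Nothing shown here explains why these groups give such similar numbers. On these data alone, every group on the carbonyl so far is a phenyl bearing fluoro or trifluoromethyl, so it remains open how an unsubstituted phenyl, a methoxyphenyl, an aminophenyl, a carboxylic acid or a pyridine ring would read in this assay at this place.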